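The source may report more compounds than this note shows. Statements on the series, on what has been measured and on what is new or still open speak of the compounds shown alone.

Working notes on the series. All four members share a core bearing an amide to a fluorinated phenyl ring: compound 1 `O=C(c1ccc(F)cc1)N1CCCC[C@@H]1c1nc(-c2cccc(F)c2)no1` and compound 2 `O=C(c1ccc(F)cc1F)N1CCCC[C@@H]1c1nc(-c2cccc(F)c2)no1` are measured, as is compound 3 `O=C(c1ccc(F)c(F)c1)N1CCCC1c1nc(-c2cccc(F)c2)no1` on a closely related core, while compound 4 `O=C(c1cccc(F)c1)N1CCCC1c1nc(-c2cccc(F)c2)no1` is not yet measured. In an in vitro functional assay on HEK293-A cells for positive allosteric modulation of metabotropic glutamate receptor 5 (Homo sapiens), read by fluorescence and calcium flux, with a stated time of 140 s (a lower number here means that less compound is needed, a higher number that more compound is needed for the effect), compound 1 gives 23000 nM and compound 2 gives 2900 nM, and in this assay compound 3 gives 3700 nM. The change from compound 2 to compound 1 is hydrogen in place of fluoro on an aromatic carbon and it made a 7.9-fold higher number from compound 2 to compound 1 (0.90 log units; beyond the scatter). The difference between the core of compound 3 and the core of compound 2 is not broken down here. Going by the values given here, compound 4 differs from compound 3 by hydrogen in place of fluoro on an aromatic carbon, which is the same kind of change as the one from compound 2 to compound 1, though not the same: in compound 2 the leaving fluoro sits ortho to a large group and meta to a fluoro group, whereas in compound 3 it sits ortho to a fluoro group and para to a large group. Among the compounds with values here, since the surroundings differ, a somewhat smaller step than the earlier one is expected in this assay, namely a 3.0-fold higher number from compound 3 to compound 4 (0.47 log units; beyond the scatter), because a 7.9-fold higher number from compound 2 to compound 1 (0.90 log units; beyond the scatter) is the only guide available. Compound 4 is accordingly estimated at 11000 nM, with a plausible range from 4000 nM to 30000 nM.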

Compound 4, half-maximal effective concentration: 2600 nM
Beside the measured number, compound 4's estimate is 4.2-fold (0.63 log units) above it; measured number below the stated range.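

In this assay the replacement of fluoro by hydrogen that turns 3,4-difluorophenyl into 3-fluorophenyl gives a 1.4-fold lower number from compound 3 to compound 4 (0.15 log units; within the scatter), a step within the scatter, and it does not match the step seen with the same kind of change on the other core: the same change on two cores in this assay, a 7.9-fold higher number (0.90 log units; beyond the scatter) from compound 2 to compound 1 and a 1.4-fold lower number (0.15 log units; within the scatter) from compound 3 to compound 4, 11-fold (1.05 log units) apart, beyond the scatter of two such steps. The size of the step therefore does not carry from the core of compound 2 to the core of compound 3, and the large step from compound 2 to compound 1 cannot serve as a guide for this pair. The two pairs differ both in the core and in the surroundings of the fluoro that leaves. The data do not separate these two differences, and two pairs give no rule for any further core.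

Open, going by these compounds, is how the 3,4-difluorophenyl and 3-fluorophenyl amides behave on the core of compound 1, a comparison that would separate the core from the ring pattern. Also open, on these data alone, is what a chloro or methoxy group would do in place of the fluoro that remains on the amide ring.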